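Exchanging the Amine Side Chain of Compound 1

A few compounds are considered here, and "the series" means these few. Any claim that something is new, unique, unknown or untested is made for them only; others in the source may bear on it.

Three amine-bearing compounds have been measured in a functional assay on HCT-116 cells (Homo sapiens) for antiproliferative activity, read by MTT assay, with a stated time of 48 h; on this read-out higher numbers stand for weaker inhibition and lower numbers for stronger inhibition. Compound 1 (`COc1cc(C(=O)/C=C/c2ccc(OCCCC(=O)NCCCCN(CCCN)CCCCN)cc2)cc(OC)c1OC`) gives 29200 nM. Compound 2 (`COc1ccc(/C=C/C(=O)c2cc(OC)c(OC)c(OC)c2)cc1OCCCC(=O)NCCCNCCCCNCCN`) gives 55800 nM, and compound 3 (`COc1ccc(/C=C/C(=O)c2cc(OC)c(OC)c(OC)c2)cc1OCCCC(=O)NCCCCN(CCCN)CCCCNCCCN`) gives 29500 nM. All three values lie within the usual scatter of one another, so compound 1 stands level with the other two on these numbers.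

Compound 4 (`COc1cc(C(=O)/C=C/c2ccc(OCCCC(=O)NCCCNCCCCNCCN)cc2)cc(OC)c1OC`) has not yet been measured in this assay. It keeps the core of compound 1, and the change is (4-((2-aminoethyl)amino)butyl)amino in place of ((4-aminobutyl)(3-aminopropyl)amino)methyl on a saturated chain carbon, three bonds along the chain from an amide-type nitrogen, on a saturated chain carbon, three bonds along the chain from an amide-type nitrogen. Going by the values given here, no measured pair isolates this exchange, so the data offer no direct guide to its size. The entering chain also occurs in compound 2, which gives 55800 nM, although that compound has a different core. On that limited evidence, only a small shift toward weaker inhibition is expected, and it should not exceed the scatter. The expected change is a 1.4-fold higher number from compound 1 to compound 4 (0.16 log units; within the scatter). Compound 4 is estimated at 42000 nM, with an expected range of 22000 nM to 80000 nM.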

Compound 4, half-maximal inhibitory concentration: 33800 nM
Estimate against measurement, compound 4: 1.2-fold (0.09 log units) above; low and high end bracket the measured number.
By their numbers in this assay, from the lowest: compounds 1, 3, 4 and 2 (each within the scatter of the next).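

In this assay, going by these compounds alone, placing (4-((2-aminoethyl)amino)butyl)amino in place of ((4-aminobutyl)(3-aminopropyl)amino)methyl on a saturated chain carbon, three bonds along the chain from an amide-type nitrogen, gives a 1.2-fold higher number from compound 1 to compound 4 (0.06 log units; within the scatter), and this is the first step to isolate a single change on one core. At this place, therefore, a group of 11 heavy atoms with 2 hydrogen-bond donors can be exchanged for one of 9 heavy atoms with 3 hydrogen-bond donors, both holding 3 nitrogens, without the number leaving the scatter. No accompanying measurement bears on why the read-out stays level across this exchange.

The compounds shown all carry chains with several amine nitrogens at this place, so they leave open whether a chain ending in a carboxylic acid, a hydroxyl group or a single amine would move the number beyond the scatter. They also leave open whether this same exchange would give a comparable step on a core other than that of compound 1.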